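The source may report more compounds than this note shows. Statements on the series, on what has been measured and on what is new or still open speak of the compounds shown alone.

Compound 1, `Cc1c(Cc2ccccc2S(=O)(=O)c2ccccc2F)c2c(n1CC(=O)O)CCNC2=O`, gives 3.6 nM in a functional assay on CHO.K1 cells for antagonist activity at prostaglandin D2 receptor 2 (Homo sapiens), read by GTPgammaS binding, with a stated time of 1 h; a higher number here means a weaker inhibitor, a lower number a stronger inhibitor.
Compound 2, `CCS(=O)(=O)c1ccccc1Cc1c2c(n(CC(=O)O)c1C)CCNC2=O`, gives 550 nM in this assay.
Compound 3, `Cc1c(Cc2ccccc2S(=O)(=O)C2CCCCC2)c2c(n1CC(=O)O)CCNC2=O`, gives 28 nM in this assay.

Compound 3 stands second highest of the three numbers: the step of a 7.8-fold higher number from compound 1 to compound 3 (0.89 log units; beyond the scatter) is modest, the step of a 20-fold lower number from compound 2 to compound 3 (1.29 log units; beyond the scatter) large. Compound 4, `Cc1c(Cc2ccccc2Cn2ccnn2)c2c(n1CC(=O)O)CCNC2=O`, differs from compound 3 by (1H-1,2,3-triazol-1-yl)methyl in place of cyclohexylsulfonyl on an aromatic carbon. Every measured step changes only the group on the sulfonyl sulfur and keeps the sulfonyl itself; the step to compound 4 removes the sulfonyl, so those steps bear on it only loosely. They do show that the group at this position moves the number widely, as in a 150-fold higher number from compound 1 to compound 2 (2.18 log units; beyond the scatter). A step towards a higher number is therefore expected, a 5.4-fold higher number from compound 3 to compound 4 (0.73 log units; beyond the scatter). Compound 4 is estimated at 150 nM, with a range from 20 nM to 1500 nM.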

Compound 4, half-maximal inhibitory concentration: 800 nM
The estimate for compound 4 lay 5.3-fold (0.73 log units) below the measured number; the range from low to high includes it.
By their numbers in this assay, from the lowest: compound 1; then compound 3; then compounds 2 and 4 (each within the scatter of the next).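

The triazolylmethyl group does not match the larger sulfonyl groups: the change gives a 29-fold higher number from compound 3 to compound 4 (1.46 log units; beyond the scatter) and a 220-fold higher number from compound 1 to compound 4 (2.35 log units; beyond the scatter) on the shared core. Against the ethylsulfonyl group, the same change gives a 1.5-fold higher number from compound 2 to compound 4 (0.16 log units; within the scatter), so this group without a sulfonyl stands level with the weakest sulfonyl shown. No measurement bears on the reason for these steps.

Going by these compounds, whether a benzyl or cyclohexylmethyl group, which also lacks the sulfonyl, would approach compound 1 remains open. So does the outcome for a sulfonamide at this position.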